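The source may hold more compounds than are shown below. What is called first, only, known or untested is meant among the compounds shown, and "the series" means these compounds.

In an ADME assay on Huh-7 cells (Homo sapiens) for cytotoxicity, with a stated time of 72 h (on this read-out higher numbers stand for lower toxicity in this test and lower numbers for higher toxicity in this test), three compounds sharing one core have been measured, and each result is a limit of the assay rather than a number. Compound 1, `CS(=O)(=O)Nc1ccc2c(c1)S(=O)(=O)N=C(C1=C(O)C3CCCC3N(C3CCCCC3)C1=O)N2`, gives > 10000 nM there, which is a limit. Compound 3, `CS(=O)(=O)Nc1ccc2c(c1)S(=O)(=O)N=C(C1=C(O)C3CCCC3N(Cc3ccc(Cl)cc3)C1=O)N2`, gives > 10000 nM, likewise a limit. Compound 2, `CS(=O)(=O)Nc1ccc2c(c1)S(=O)(=O)N=C(C1=C(O)[C@H]3CCC[C@H]3N(Cc3ccc(F)c(Cl)c3)C1=O)N2`, gives > 1000 nM, again a limit, so compound 2 stands at the limit of > 1000 nM in this assay, at which 1 of the 3 values shown sits, while the other two values sit at the limit of > 10000 nM in this assay, at which 2 of the 3 values shown sit. Going by the values given here, the one step between measured compounds, a step that the two limits leave unreadable from compound 1 to compound 3, cannot be read in size, since both of its ends are limits.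

Compound 4 is `CS(=O)(=O)Nc1ccc2c(c1)S(=O)(=O)N=C(C1=C(O)[C@H]3CCC[C@H]3N(CC3CC3)C1=O)N2`. Its change from compound 2 is cyclopropyl in place of 3-chloro-4-fluorophenyl on a saturated chain carbon bound to an amide-type nitrogen in a ring. Among the compounds with values here, no measured step bears on this change with a readable size; the only evidence is that every value so far sits at a limit. There is thus no step in either direction to carry forward, and the expectation is that compound 4 will again show low toxicity in this assay, most probably reported as a limit once more. The estimated value for compound 4 is 15000 nM, with a range from 2000 nM to 100000 nM. The step this estimate implies, a step that the limit leaves unreadable from compound 2 to compound 4, is expected to stay within the usual scatter.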

Compound 4, half-maximal cytotoxic concentration: > 33000 nM
Compound 4: no number, only a limit; the forecaster's own chance of this, stated with the estimate: 75%; middle value at least 2.2-fold (0.34 log units) away from the limit.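

Compound 2 and compound 4 both end at limits of the assay, not at numbers, so the step between them cannot be read in size. The compounds shown leave open the concentration at which any of them would become toxic in this assay, and whether cyclopropylmethyl in place of 3-chloro-4-fluorobenzyl changes that result at all.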